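Hydrogen for methoxy on compound 3: notes

This account rests on a few compounds, and the source may have more. Where it says the series, first, only, none or still open, it means among the compounds named here.

Values in a functional assay on A549 cells (Homo sapiens) for antiproliferative activity, read by MTT assay, with a stated time of 48 h (on this read-out higher numbers stand for weaker inhibition and lower numbers for stronger inhibition), so far:
- compound 1 `COc1cccc(-c2nn(-c3ccccc3)cc2C(Nc2nc3ccc(OC)cc3s2)c2c(O)ccc3ccccc23)c1` gives 88100 nM
- compound 2 `COc1ccc2nc(NC(c3cn(-c4ccccc4)nc3-c3ccccc3)c3c(O)ccc4ccccc34)sc2c1` gives 44600 nM
- compound 3 `COc1cccc(-c2nn(-c3ccccc3)cc2C(Nc2nc3ccc(Cl)cc3s2)c2c(O)ccc3ccccc23)c1` gives 49800 nM

The three values lie within the scatter of one another, so compound 3 has no separate standing among them. Compound 4 `Oc1ccc2ccccc2c1C(Nc1nc2ccc(Cl)cc2s1)c1cn(-c2ccccc2)nc1-c1ccccc1` is reached from compound 3 by one change (hydrogen in place of methoxy on an aromatic carbon), hydrogen in place of methoxy on an aromatic carbon, which reads as 3-methoxyphenyl to phenyl. The same replacement has one measured precedent (a 2.0-fold lower number from compound 1 to compound 2 (0.30 log units; within the scatter)), and that step stays within the scatter. Chloro in place of methoxy on an aromatic carbon is a different replacement (a 1.8-fold lower number from compound 1 to compound 3 (0.25 log units; within the scatter)), also within the scatter, and it bears only loosely on this change. In this assay a small move toward a lower number is therefore expected, and nothing beyond the scatter. The estimated step is small (a 1.8-fold lower number from compound 3 to compound 4 (0.25 log units; within the scatter)) and rests on that single precedent. The expected value for compound 4 is 28000 nM (estimated range 13000 nM to 58000 nM)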

Compound 4, half-maximal inhibitory concentration: 51100 nM
Beside the measured number, compound 4's estimate is 1.8-fold (0.26 log units) below it; the measured number falls inside the stated range.
By their numbers in this assay, from the lowest: compounds 2, 3, 4 and 1 (each within the scatter of the next).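

In this assay the change from 3-methoxyphenyl to phenyl now has a second reading, a 1.0-fold higher number from compound 3 to compound 4 (0.01 log units; within the scatter) on the core of compound 3, so this position shows no step beyond the scatter on either core. The two readings of this change agree: the same change on two cores in this assay, a 2.0-fold lower number (0.30 log units; within the scatter) from compound 1 to compound 2 and a 1.0-fold higher number (0.01 log units; within the scatter) from compound 3 to compound 4, 2.0-fold (0.31 log units) apart, within the scatter of two such steps. Chloro in place of methoxy now also has a second reading, a 1.1-fold higher number from compound 2 to compound 4 (0.06 log units; within the scatter) with phenyl in the place of 3-methoxyphenyl, and it agrees with the first: the same change on two cores in this assay, a 1.8-fold lower number (0.25 log units; within the scatter) from compound 1 to compound 3 and a 1.1-fold higher number (0.06 log units; within the scatter) from compound 2 to compound 4, 2.0-fold (0.31 log units) apart, within the scatter of two such steps.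

The compounds shown carry only methoxy or hydrogen at this place on the ring, so they span a narrow set of groups. From the compounds shown here alone, whether an amine or a carboxylic acid there would give a step beyond the scatter stays open.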